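This account rests on a few compounds, and the source may have more. Where it says the series, first, only, none or still open, it means among the compounds named here.

In a functional assay, with a stated time of 30 min (a higher number here means a weaker inhibitor, a lower number a stronger inhibitor), compound 1 `O=C(/C=C/c1cccc(O)c1O)CC(=O)/C=C/c1cccc(O)c1O` gives 30000 nM and compound 2 `O=C(/C=C/c1ccccc1O)CC(=O)/C=C/c1cccc(O)c1O` gives 23000 nM, so compound 2 stands level with compound 1 within the scatter. Among the compounds with values here, the only measured step, a 1.3-fold lower number from compound 1 to compound 2 (0.12 log units; within the scatter), places hydrogen in place of hydroxy on an aromatic carbon. Compound 3 `O=C(/C=C/c1cccc(O)c1)CC(=O)/C=C/c1cccc(O)c1O` differs from compound 2 as follows: 3-hydroxyphenyl in place of 2-hydroxyphenyl on a double-bonded chain carbon bound to a double-bonded chain carbon. Within the data shown here, no measured step tests this exact change, so the small size of a 1.3-fold lower number from compound 1 to compound 2 (0.12 log units; within the scatter) is only a weak guide, and no shift beyond the scatter is expected in this assay. The estimated step is a 1.1-fold higher number from compound 2 to compound 3 (0.04 log units; within the scatter). For compound 3 the estimate is 25000 nM, with an expected range of 10000 nM to 60000 nM.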

Compound 3, half-maximal inhibitory concentration: 29000 nM
Estimate against measurement, compound 3: 1.2-fold (0.06 log units) below; the measured number falls inside the stated range.
By their numbers in this assay, from the lowest: compounds 2, 3 and 1 (each within the scatter of the next).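

In this assay, within the data shown here, hydroxy placement on this ring is tested for the first time: 3-hydroxyphenyl in place of 2-hydroxyphenyl on a double-bonded chain carbon bound to a double-bonded chain carbon gives a 1.3-fold higher number from compound 2 to compound 3 (0.10 log units; within the scatter) and so leaves the number within the scatter. Hydrogen in place of hydroxy on an aromatic carbon, now seen a second time as a 1.0-fold lower number from compound 1 to compound 3 (0.01 log units; within the scatter), also stays within the scatter, as it did in the earlier step. No evidence is available that bears on this result.
The compounds shown carry only hydroxy on this ring, so whether any group here can move the number beyond the scatter stays open. A methoxy group, an amine or a carboxylic acid in this place would test that.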